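Swapping methyl for cyclopropyl on the shared core

The source may report more compounds than this note shows. Statements on the series, on what has been measured and on what is new or still open speak of the compounds shown alone.

Compounds measured so far:
- compound 1, `Cc1c(C(=O)Nc2ccc(Oc3ncnc4[nH]cc(-c5ccccc5)c34)c(F)c2)c(=O)c2cc(F)ccc2n1C`, in an assay on isolated protein for inhibition of tyrosine-protein kinase receptor UFO (Homo sapiens), read by FRET and Z'-LYTE, with a stated time of 1.5 h (a higher number here means a weaker inhibitor, a lower number a stronger inhibitor), compound 1 gives > 10000 nM, which is a limit of the assay rather than a number
- compound 2, `Cc1c(C(=O)Nc2ccc(Oc3ncnc4[nH]cc(-c5ccccc5)c34)c(F)c2)c(=O)c2cc(Br)ccc2n1C`, in this assay compound 2 gives 3120 nM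
- compound 3, `Cc1ccc2c(c1)c(=O)c(C(=O)Nc1ccc(Oc3ncnc4[nH]cc(-c5ccccc5)c34)c(F)c1)c(C)n2C`, in this assay compound 3 gives 100 nM

Compound 3 has the lowest number of the three, and therefore the strongest inhibition shown. Its nearest measured neighbour is compound 2, and the step of a 31-fold lower number from compound 2 to compound 3 (1.49 log units; beyond the scatter) is large. Compound 1 sits at a limit, (the limit of > 10000 nM in this assay, at which 1 of the 3 values shown sits), so the step of an at least 100-fold lower number from compound 1 to compound 3 (2.00 log units; beyond the scatter) can only be given as a lower bound. The step of an at least 3.2-fold lower number from compound 1 to compound 2 (0.50 log units; beyond the scatter) is at least modest.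

Compound 4, `Cc1c(C(=O)Nc2ccc(Oc3ncnc4[nH]cc(-c5ccccc5)c34)c(F)c2)c(=O)c2cc(C3CC3)ccc2n1C`, has not yet been measured. It differs from compound 3 by cyclopropyl in place of methyl on an aromatic carbon. Among the measured steps, those that change the group at this same place all bear on it: fluoro to bromo to methyl, where methyl proved best. None of them introduces a ring, so the measured steps give only weak guidance here. A modest loss in this assay seems the likeliest outcome, with wide uncertainty.

Compound 4 is expected to give 250 nM, between 60 nM and 1500 nM. For compound 4 this estimate amounts to a step of a 2.5-fold higher number from compound 3 to compound 4 (0.40 log units; beyond the scatter), an expectation only.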

Compound 4, half-maximal inhibitory concentration: 230 nM
Estimate against measurement, compound 4: 1.1-fold (0.04 log units) above; the range from low to high includes it.
By their numbers in this assay, from the lowest: compound 3; then compound 4; then compound 2. At a limit, above all of these: compound 1.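

The position accepts a ring: replacing bromo with cyclopropyl, which brings three heavy atoms and a three-membered ring, gives a 14-fold lower number from compound 2 to compound 4 (1.13 log units; beyond the scatter) in this assay. Methyl still gives the lowest number of the four, but the step to the ring is only modest, a 2.3-fold higher number from compound 3 to compound 4 (0.36 log units; beyond the scatter), so both carbon groups remain well ahead of bromo. The step from the fluoro compound, an at least 43-fold lower number from compound 1 to compound 4 (1.63 log units; beyond the scatter), rests on a limit and is only a lower bound: the limit of > 10000 nM in this assay, at which 1 of the 4 values shown sits.

The compounds shown carry only halogens and small hydrocarbon groups here, leaving open whether an ethyl group, a methoxy group or an amine would keep this level of inhibition. They also do not show why methyl and cyclopropyl stand so far ahead of the halogens.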